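Exposure after a morpholine replaces an isopropyl sulfone

This account rests on a few compounds, and the source may have more. Where it says the series, first, only, none or still open, it means among the compounds named here.

Measured so far:
- compound 1, `CN1CCC2(CC1)CC(S(=O)(=O)c1c(Cl)ccc(NC(=O)Nc3cccc(F)c3Cl)c1O)C2`: 1390 ng.h/mL
- compound 2, `CC(C)S(=O)(=O)c1c(Cl)ccc(NC(=O)Nc2cccc(Cl)c2Cl)c1O`: 290 ng.h/mL

Of the compounds shown here, two have been measured in an ADME assay on the whole organism (blood, Mus musculus, strain C57BL/6) for pharmacokinetics, read by HPLC, with a stated time of 4 h, at a dose of 2 mg/kg by the intraperitoneal route; a higher number here means more compound in the circulation at the dose given, a lower number less compound in the circulation. Compound 1 gives 1390 ng.h/mL, while compound 2 gives 290 ng.h/mL, the lower of the two numbers and a gap that lies beyond the usual scatter of this assay. Compound 2 is therefore the starting point with the lower exposure.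

The next compound, compound 3, `C[C@@H]1CN(S(=O)(=O)c2c(Cl)ccc(NC(=O)Nc3cccc(Cl)c3Cl)c2O)C[C@H](C)O1`, is built from compound 2 by a single change: 2,6-dimethylmorpholin-4-yl in place of isopropyl on a sulfonyl sulfur. The shared core carrying the urea and the chlorinated phenol is untouched.

Among the compounds with values here, no step between measured compounds maps exactly onto this change, so the expectation rests on the two values alone. Compound 1, which carries a ring-containing group on the same sulfonyl sulfur, sits well above compound 2, so a move toward higher exposure in this assay seems more likely than a move downward, though a shift no larger than the scatter is also plausible. The expected step from compound 2 to compound 3 is a 1.6-fold higher number from compound 2 to compound 3 (0.19 log units; within the scatter). Compound 3 is estimated at 450 ng.h/mL, within a range from 180 ng.h/mL to 1100 ng.h/mL.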

Compound 3, area under the concentration-time curve: 519 ng.h/mL
Compound 3: middle estimate off by 1.2-fold (0.06 log units), on the low side, within the range that was stated.
By their numbers in this assay, from the lowest: compounds 2 and 3 (each within the scatter of the next); then compound 1.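

In this assay, the sulfonyl sulfur takes a much larger group than isopropyl with no clear effect on exposure: 2,6-dimethylmorpholin-4-yl brings 8 heavy atoms in place of 3, along with a ring and a hydrogen-bond acceptor, yet the swap gives a 1.8-fold higher number from compound 2 to compound 3 (0.25 log units; within the scatter), a step too small to count as a real gain or loss. This is the only direct reading of this position among the compounds shown, as compound 1 differs from compound 2 in more than one place and so could not isolate the effect of the sulfonyl substituent. No separate measurement on these compounds bears on why the swap leaves exposure so little changed.

Going by these compounds, it remains open whether the ring, its oxygen, the two methyl groups or their defined stereochemistry matter individually, which a plain morpholine, a piperidine or an open-chain dimethylamino group on the same sulfur could help to separate. Also unknown is whether a basic amine on that sulfur, tested on an otherwise unchanged core, would shift the number by more than the usual scatter.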